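The source may hold more compounds than are shown below. What is called first, only, known or untested is meant among the compounds shown, and "the series" means these compounds.

The measured compounds in this study:

Compound 1, `Cn1c(C(=O)NCc2ccc(S(=O)(=O)c3ccccc3)cc2)cc2cnccc21`, gives > 10000 nM.
Compound 2, `O=C(NCc1ccc(S(=O)(=O)c2ccccc2)cc1)c1cc2ccncc2s1`, gives 14 nM.
Compound 3, `O=C(NCc1ccc(S(=O)(=O)c2ccccc2)cc1)c1cc(-c2cccnc2)no1`, gives > 10000 nM.

Among the compounds with values here, in a functional assay on A2780 cells (Homo sapiens) for inhibition, read by sulforhodamine B assay, with a stated time of 72 h (a lower number here means a stronger inhibitor, a higher number a weaker inhibitor), compound 2 stands alone as the only measured number, with 14 nM. The other two results are limits of the assay rather than numbers. Compound 1 reaches only the limit of > 10000 nM. Compound 3 likewise reaches only the limit of > 10000 nM. Within the data shown here, the picture is therefore dominated by the limit of > 10000 nM in this assay, at which 2 of the 3 values shown sit, and no step between two measured compounds can be counted.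

Compound 4, `O=C(NCc1ccc(S(=O)(=O)c2ccccc2)cc1)c1cn2ccnc2cn1`, has not yet been measured in this assay. It differs from compound 2 as follows: a group of 9 heavy atoms (6 carbon, 3 nitrogen; one five-membered aromatic ring with 2 hetero atoms, one six-membered aromatic ring with 2 hetero atoms) in place of a group of 9 heavy atoms (7 carbon, 1 nitrogen, 1 sulfur; one five-membered aromatic ring with 1 hetero atom, one six-membered aromatic ring with 1 hetero atom), on a carbonyl carbon. Among the measured compounds shown here, the group that leaves is the one carried by the only compound with a measured number, and the two compounds carrying other groups on the same carbonyl carbon sit at the limit.

On that basis compound 4 is expected to be weaker than compound 2, with an expected step of a 71-fold higher number from compound 2 to compound 4 (1.85 log units; beyond the scatter), well beyond the scatter. The estimate for compound 4 in this assay is 1000 nM, in a range from 100 nM to 10000 nM, with a real chance that only a limit is reported.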

Compound 4, half-maximal inhibitory concentration: > 10000 nM
Compound 4 ended at the assay's limit (the forecaster's own chance of this, stated with the estimate: 35%); middle value at least 10-fold (1.00 log units) away from the limit.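

In this assay, within the data shown here, the change on the carbonyl carbon gives an at least 710-fold higher number from compound 2 to compound 4 (2.85 log units; beyond the scatter), the first step at this place that can be read at all, though it rests on a limit at one end. The entering group matches the leaving one in its 9 heavy atoms, its one five-membered and one six-membered aromatic ring and its 0 hydrogen-bond donors, so this match in counts alone does not keep the low number of compound 2; the groups differ in their atoms, with 3 nitrogen and no sulfur entering, and in having 3 rather than 2 hydrogen-bond acceptors. Compound 4 gives > 10000 nM, which is a limit of the assay, and the only number at this place remains that of compound 2, so the set now stands as follows: the limit of > 10000 nM in this assay, at which 3 of the 4 values shown sit.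

The compounds shown leave open whether the sulfur of the leaving group or the placing of its nitrogen matters more, as no pair here changes just one of these. They also leave open what a naphthyl group or a plain phenyl ring would give on the same carbonyl carbon.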